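This account rests on a few compounds, and the source may have more. Where it says the series, first, only, none or still open, it means among the compounds named here.

Working notes on a short cyanoguanidine series measured in an in vitro functional assay on Sf9 cells for antagonist activity at histamine H2 receptor (Homo sapiens); on this read-out higher numbers stand for higher potency (the scale is a negative logarithm) and lower numbers for lower potency.

Compound 1 `N#C/N=C(\NCCCCc1ccccc1)NCCCc1c[nH]cn1` gives 5.03. Compound 2 `N#C/N=C(\NCCCCc1ccccc1)NCCCCc1c[nH]cn1` gives 5.03, and the step from compound 1 to compound 2, no change at the digits printed from compound 1 to compound 2 (within the scatter), shows no shift when the imidazole is moved out by one chain carbon. Compound 3 `N#C/N=C(/NCCCCc1c[nH]cn1)NCCC(c1ccccc1)c1ccccc1` gives 5, which lies within the scatter of compound 2. Compound 2 thus stands level with compound 1, and all three numbers sit together within the usual scatter.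

Compound 4 `N#C/N=C(/NCCCCc1c[nH]cn1)NCCCc1ccc(F)cc1` is not yet measured. It differs from compound 2 by 4-fluorophenyl in place of benzyl on a saturated chain carbon, three bonds along the chain from an amine nitrogen. Within the data shown here, none of the measured steps touches the aryl end of the chain; the one measured step, on the imidazole side, was flat, and the change from one phenyl to two phenyls between compound 2 and compound 3 also left the number where it was. With nothing in the series pointing to a shift, no step beyond the scatter is expected in this assay, a number 0.03 log units lower from compound 2 to compound 4 (within the scatter). The estimate for compound 4 is 5, expected to fall between 4.6 and 5.5.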

Compound 4, negative logarithm of the antagonist equilibrium constant: 5.28
The estimate for compound 4 lay 0.28 log units below the measured number; the range from low to high includes it.
By their numbers in this assay, from the lowest: compounds 3, 1, 2 and 4 (each within the scatter of the next).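

In this assay, the aryl end of the chain now has a measured step of its own: a number 0.25 log units higher from compound 2 to compound 4 (within the scatter) for 4-fluorophenyl in place of benzyl on a saturated chain carbon, three bonds along the chain from an amine nitrogen. This position therefore tolerates the change without a step beyond the scatter, although the swap alters both the ring substituent and the chain length, and this single step does not separate the two. No measurement at hand bears on the cause of this result.

The compounds shown leave open whether a chlorine or a methoxy group in place of the fluorine would give a step beyond the scatter. On these data alone, it also remains open whether a pyridine ring in place of the fluorinated phenyl ring would do so.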